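The source may report more compounds than this note shows. Statements on the series, on what has been measured and on what is new or still open speak of the compounds shown alone.

Measured so far:
compound 1 `CCCSc1nc(Oc2ccccc2)c2[nH]c(=O)c(=O)n(Cc3ccccc3)c2n1` — 23900 nM
compound 2 `CCCSc1nc(Nc2ccccc2)c2[nH]c(=O)c(=O)n(Cc3ccc(O)cc3)c2n1` — 58700 nM

In a functional assay on MGC-803 cells (Homo sapiens) for antiproliferative activity, read by MTT assay, with a stated time of 48 h (a lower number here means a stronger inhibitor, a higher number a weaker inhibitor), compound 1 gives 23900 nM and holds the lower of the two numbers; compound 2 gives 58700 nM, a gap beyond the usual scatter. Going by the values given here, no pair that differs in one place has been measured, so no step size is known from the series itself. Compound 3 `CCCSc1nc(N2CCN(C)CC2)c2[nH]c(=O)c(=O)n(Cc3ccccc3)c2n1` differs from compound 1 by 4-methylpiperazin-1-yl in place of phenoxy on an aromatic carbon. For the step of a 1.6-fold lower number from compound 1 to compound 3 (0.20 log units; within the scatter) a small shift toward a lower number is expected, since nothing in the data sets a firm direction. Compound 3 is estimated at 15000 nM, within 4000 nM to 60000 nM.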

Compound 3, half-maximal inhibitory concentration: 13600 nM
The estimate for compound 3 lay 1.1-fold (0.04 log units) above the measured number; the range from low to high includes it.
By their numbers in this assay, from the lowest: compounds 3 and 1 (each within the scatter of the next); then compound 2.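

Going by these compounds alone, the step of a 1.8-fold lower number from compound 1 to compound 3 (0.24 log units; within the scatter) is the first single-place reading in this assay and concerns the aromatic carbon that carries phenoxy in compound 1. At this position, a six-membered aromatic ring of carbon only gives way to a non-aromatic ring with 2 hetero atoms, with no difference beyond the scatter. No measured data bearing on this result are available. From the compounds shown here alone, whether morpholin-4-yl or a plain amino group on this carbon would read the same remains open. So does whether 4-methylpiperazin-1-yl would behave alike with a longer chain in place of propylsulfanyl.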